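Sulfur substituent change from compound 3 to compound 4

The source may report more compounds than this note shows. Statements on the series, on what has been measured and on what is new or still open speak of the compounds shown alone.

Compound 3 `Nc1ccccc1NC(=O)c1ccc(CSc2cccc(F)c2)cc1` stands highest of the three measured compounds in a functional assay on HCT-116 cells (Homo sapiens) for inhibition, read by CCK-8 assay, with a stated time of 72 h, tested at 8 uM (on this read-out lower numbers stand for less inhibition of growth and higher numbers for more inhibition of growth at the one concentration tested), where compound 3 gives 81.4%. Compound 1 `Nc1ccccc1NC(=O)/C=C/c1ccc(CSc2ccc(Cl)cc2)cc1` gives 3.27% and compound 2 `Cc1cc(C)cc(SCc2ccc(/C=C/C(=O)Nc3ccccc3N)cc2)c1` gives 4.2%; both share a core that differs from that of compound 3. For the measured compounds named here, the only measured step on the sulfur, a number 0.9 percentage points higher from compound 1 to compound 2 (within the scatter), is within the scatter, so exchanging the group on the sulfur changed little there, though on another core. Compound 4 `Nc1ccccc1NC(=O)c1ccc(CSCCc2ccccc2)cc1` differs from compound 3 by phenethyl in place of 3-fluorophenyl on a sulfur. Going by the values given here, no measured step covers an aryl-to-phenethyl exchange, so the expectation rests on compound 3 alone. Compound 4 is expected to keep most of the inhibition, with a number 16.4 percentage points lower from compound 3 to compound 4 (beyond the scatter), giving an estimated 65% within 30% to 90%.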

Compound 4, percent growth inhibition at one concentration: 81.3%
For compound 4 the middle estimate is 16.3 percentage points below the measured one, and the stated range covers the measured number.
By their numbers in this assay, from the lowest: compounds 1 and 2 (each within the scatter of the next); then compounds 4 and 3 (each within the scatter of the next).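

With phenethyl in place of 3-fluorophenyl on a sulfur, this assay shows a number 0.1 percentage points lower from compound 3 to compound 4 (within the scatter), so inhibition of growth on this core does not depend on an aryl group sitting directly on the sulfur. Unlike the earlier step on the sulfur, which stood on the core of compound 1 at far lower numbers, this step shows the exchange holding at a high level. Nothing measured here explains why the two groups read alike.

Going by these compounds, whether a plain alkyl chain without an aromatic ring, or a chain ending in an amine or a carboxylic acid, would hold the number on the sulfur stays open. A single concentration also leaves open whether the two compounds would still read alike at lower concentrations.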